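The compounds below may be only part of what the source reports. "The series", "measured", "known", "first", "only" and "open" are said of these compounds alone.

Compound 1 (`COc1cccc(C=C2C(=O)N(c3ccc(Cl)cc3)N(c3ccc(Cl)cc3)C2=O)c1O`): 26700 nM
Compound 2 (`COc1ccc(C=C2C(=O)N(c3ccc(Cl)cc3)N(c3ccc(Cl)cc3)C2=O)cc1`): > 128000 nM

In a functional assay on MCF7 cells (Homo sapiens) for cytotoxicity, read by MTT assay, with a stated time of 72 h (a lower number here means a stronger inhibitor, a higher number a weaker inhibitor), compound 1 gives 26700 nM as a measured number. For compound 2 the result > 128000 nM is a limit of the assay and not a number, so the limit of > 128000 nM in this assay, at which 1 of the 2 values shown sits, is where compound 2 stands.

Compared with compound 2, compound 3 (`COc1cccc(C=C2C(=O)N(c3ccc(Cl)cc3)N(c3ccc(Cl)cc3)C2=O)c1OC`) carries 2,3-dimethoxyphenyl in place of 4-methoxyphenyl on a double-bonded chain carbon bound to a double-bonded ring carbon.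

Among the compounds with values here, only one measured step bears on this change. The step of an at least 4.7-fold higher number from compound 1 to compound 2 (0.68 log units; beyond the scatter) put 4-methoxyphenyl in place of 2-hydroxy-3-methoxyphenyl at the same place, and it lies beyond the scatter. By name, the 2,3-dimethoxyphenyl group of compound 3 is closer to the group of compound 1 (26700 nM), with methoxy where that group has hydroxy. In this assay a move to a lower number than the limit of compound 2 is therefore expected, though part of the earlier step may not return.

The estimate therefore means an at least 2.1-fold lower number from compound 2 to compound 3 (0.32 log units; beyond the scatter) as the expected step. For compound 3 the estimate is 60000 nM within an expected range from 22000 nM to 128000 nM (estimated, not measured).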

Compound 3, half-maximal inhibitory concentration: 11900 nM
Estimate against measurement, compound 3: 5.0-fold (0.70 log units) above, and the stated range ends above it.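

In this assay, the hydroxy group of compound 1 turns out not to be required for a measurable result: with methyl in place of hydrogen on that oxygen, the outcome is a 2.2-fold lower number from compound 1 to compound 3 (0.35 log units; beyond the scatter). Swapping 4-methoxyphenyl for 2,3-dimethoxyphenyl gives an at least 10-fold lower number from compound 2 to compound 3 (1.03 log units; beyond the scatter), so among these three compounds a ring without hydroxy can still give a measured number, and the arrangement of the methoxy groups on the ring makes a clear difference. The size of that step is only a lower bound, as the result for compound 2 is a limit and not a number: the limit of > 128000 nM in this assay, at which 1 of the 3 values shown sits.

The compounds shown leave open whether both methoxy groups of 2,3-dimethoxyphenyl are needed, or whether one alone, in either of those two places on the ring, would give a similar result. They also leave open how a quite different group on the ring, such as an amine or a carboxylic acid, would behave at this same place on the double-bonded chain carbon.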